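The source may hold more compounds than are shown below. What is called first, only, known or untested is meant among the compounds shown, and "the series" means these compounds.

Of the compounds shown here, three that share one core have so far been tested in a functional assay on CHO cells with adenosine receptor A1 (Homo sapiens) as the target, read by cAMP accumulation and immunoassay, with a stated time of 6 min, tested at 1 uM; a lower number here means a stronger effect, a higher number a weaker effect of the compound at the concentration tested. Compound 1 `Nc1scc(CN2CCN(c3ccc(F)cc3Cl)CC2)c1C(=O)c1ccc(Cl)cc1` gives -39%. Compound 2 `Nc1scc(CN2CCN(C3CCCCCC3)CC2)c1C(=O)c1ccc(Cl)cc1` gives 3.7%. Compound 3 `Nc1scc(CN2CCN(c3ccc(F)c(Cl)c3)CC2)c1C(=O)c1ccc(Cl)cc1` gives -60%, the lowest of the three numbers: the step of a number 21 percentage points lower from compound 1 to compound 3 (beyond the scatter) sets it beyond the scatter from its nearest neighbour, and the step of a number 63.7 percentage points lower from compound 2 to compound 3 (beyond the scatter) sets it far from compound 2.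

Compound 4 `Nc1scc(CN2CCN(CCCc3ccc(Cl)cc3)CC2)c1C(=O)c1ccc(Cl)cc1` has not yet been measured. It differs from compound 3 in one place: 3-(4-chlorophenyl)propyl in place of 3-chloro-4-fluorophenyl on an amine nitrogen in a ring.

Two measured steps speak to this change. Both steps that exchange an aromatic ring on the ring nitrogen for a non-aromatic group were large, namely a number 42.7 percentage points higher from compound 1 to compound 2 (beyond the scatter) and a number 63.7 percentage points lower from compound 2 to compound 3 (beyond the scatter), whereas the step that only shifts the chlorine within the aromatic ring, a number 21 percentage points lower from compound 1 to compound 3 (beyond the scatter), was modest. Compound 4 lies between these cases: the ring nitrogen bears a chain, as in compound 2, yet that chain carries a chlorine-bearing aromatic ring, as in compound 1 and compound 3. Going by the values given here, no measured step reproduces this exactly, so the expectation is a step upward that falls short of the value of compound 2. The expected step is a number 45 percentage points higher from compound 3 to compound 4 (beyond the scatter). Compound 4 is therefore estimated at -15%, with a range from -50% to 15%.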

Compound 4, a percentage reported as activity, at one concentration (the size of the read-out at that concentration, not a potency): -30%
Compound 4: the middle estimate sits 15 percentage points above what was measured, and the stated range covers the measured number.
By their numbers in this assay, from the lowest: compound 3; then compounds 1 and 4 (each within the scatter of the next); then compound 2.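

In this assay, going by these compounds alone, the step of a number 33.7 percentage points lower from compound 2 to compound 4 (beyond the scatter) shows that an aromatic ring can still give a much lower number than cycloheptyl when a propyl chain separates it from the amine nitrogen in the ring, a case the earlier compounds did not cover. The step of a number 9 percentage points higher from compound 1 to compound 4 (within the scatter) means that 3-(4-chlorophenyl)propyl and 2-chloro-4-fluorophenyl cannot be told apart at this position, even though the first group has the longer reach and 10 heavy atoms rather than 8. Yet the step of a number 30 percentage points higher from compound 3 to compound 4 (beyond the scatter) keeps 3-chloro-4-fluorophenyl apart from the chain-bearing group, and compound 3 retains the lowest number of the four, so a chain-linked aromatic ring matches one ring pattern here but not the other.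

The compounds shown leave open how the number moves with a benzyl group, a shorter two-carbon chain or a longer butyl chain, and whether the chlorine on the chain's ring matters, as a plain 3-phenylpropyl group would test. No measurement at hand accounts for any of these differences.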